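The source may hold more compounds than are shown below. What is called first, only, known or untested is meant among the compounds shown, and "the series" means these compounds.

Measured compounds:
compound 1 `COc1ccccc1N1C(=O)CSC1c1cc(F)cc(C(=O)NCCCCc2ccccc2)c1`: 2170 mL.min-1.g-1
compound 2 `COc1ccc(F)cc1N1C(=O)CSC1c1cccc(C(=O)NCCCCc2ccccc2)c1`: 1650 mL.min-1.g-1
compound 3 `O=C(NCCCCc1ccccc1)c1cccc(C2SCC(=O)N2c2ccccn2)c1`: 492 mL.min-1.g-1

In an ADME assay on microsomes from liver (Canis lupus familiaris) for metabolic stability, read by LC-MS, using NADPH, with a stated time of 10 min, tested at 0.1 uM (on this read-out higher numbers stand for fast clearance and lower numbers for slow clearance), compound 2 gives 1650 mL.min-1.g-1, the second highest of these three numbers; compound 1 lies within the scatter of it, while compound 3 lies beyond the scatter, at a lower number. Compound 4 `O=C(NCCCCc1ccccc1)c1cccc(C2SCC(=O)N2c2ccc(C3CC3)cc2)c1` differs from compound 2 by 4-cyclopropylphenyl in place of 5-fluoro-2-methoxyphenyl on an amide-type nitrogen in a ring. Among the measured compounds shown here, the only measured step at this position is a 3.4-fold lower number from compound 2 to compound 3 (0.53 log units; beyond the scatter), which shows that changing the group on the ring nitrogen can shift the number, but the group entering there is not the one entering in compound 4, so it gives only a loose guide. With no closer comparison, compound 4 is expected to stay near compound 2 within the scatter, with a wide range. Compound 4 is estimated at 1500 mL.min-1.g-1 (range 600 mL.min-1.g-1 to 3500 mL.min-1.g-1), a step of a 1.1-fold lower number from compound 2 to compound 4 (0.04 log units; within the scatter).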

Compound 4, intrinsic clearance in microsomes: 1080 mL.min-1.g-1
Compound 4: middle estimate off by 1.4-fold (0.14 log units), on the high side; the range from low to high includes it.
By their numbers in this assay, from the lowest: compound 3; then compounds 4, 2 and 1 (each within the scatter of the next).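

In this assay, 4-cyclopropylphenyl on the ring nitrogen gives a 1.5-fold lower number from compound 2 to compound 4 (0.18 log units; within the scatter), so two quite differently substituted phenyl groups stay within the scatter of each other. Pyridin-2-yl stands apart, with a 2.2-fold higher number from compound 3 to compound 4 (0.34 log units; beyond the scatter), and among compounds 2, 3 and 4 it is the only group at this place with a clearly lower number. No measurement shown here explains this difference. Still open, going by these compounds, is whether plain phenyl would stay with compounds 2 and 4, and whether pyridin-3-yl would match compound 3.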